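A few compounds are considered here, and "the series" means these few. Any claim that something is new, unique, unknown or untested is made for them only; others in the source may bear on it.

Compound 1 `CNS(=O)(=O)c1ccc(C)c(C#Cc2cc(Cl)ccc2OCC(=O)O)c1`: 10 nM
Compound 2 `O=C(O)COc1ccc(Cl)cc1C#Cc1ccccc1Cl`: 28 nM
Compound 3 `Cn1ccnc1C#Cc1cc(Cl)ccc1OCC(=O)O`: 1470 nM

Of the compounds shown here, three sharing one core have been measured in an assay on CHO cells for displacement of a labelled ligand from prostaglandin D2 receptor 2 (Homo sapiens), read by scintillation counting; a lower number here means a stronger inhibitor, a higher number a weaker inhibitor. Compound 3 gives the highest number of the three, with 1470 nM; its nearest neighbour is compound 2, which gives 28 nM, and the furthest is compound 1, which gives 10 nM. Within the data shown here, the only single-change step among the measured compounds is a 53-fold higher number from compound 2 to compound 3 (1.72 log units; beyond the scatter), where 1-methyl-1H-imidazol-2-yl replaced 2-chlorophenyl on the triple-bonded carbon.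

Compound 4 `O=C(O)COc1ccc(Cl)cc1C#Cc1ccc(Cl)cc1` has not yet been measured in this assay. It differs from compound 3 in one place: 4-chlorophenyl in place of 1-methyl-1H-imidazol-2-yl on a triple-bonded carbon. This change runs the earlier step backwards in kind, a 4-chlorophenyl again taking the place of the five-membered ring on a triple-bonded carbon, though the chlorine now sits elsewhere on the ring than in compound 2. Because the step of a 53-fold higher number from compound 2 to compound 3 (1.72 log units; beyond the scatter) was large, compound 4 is expected to show a step of about a 37-fold lower number from compound 3 to compound 4 (1.57 log units; beyond the scatter), a much lower number than compound 3. The estimate for compound 4 in this assay is 40 nM, within a range of 10 nM to 200 nM.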

Compound 4, inhibition constant: 60 nM
Compound 4: middle estimate off by 1.5-fold (0.18 log units), on the low side; the range from low to high includes it.
By their numbers in this assay, from the lowest: compound 1; then compound 2; then compound 4; then compound 3.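

In this assay, the large 25-fold lower number from compound 3 to compound 4 (1.39 log units; beyond the scatter) shows that the high number of compound 3 is not tied to one particular aryl group: 4-chlorophenyl on the triple-bonded carbon, like 2-chlorophenyl, gives a far lower number than 1-methyl-1H-imidazol-2-yl. The a 2.1-fold higher number from compound 2 to compound 4 (0.33 log units; beyond the scatter) is beyond the scatter but modest, and much smaller than a 53-fold higher number from compound 2 to compound 3 (1.72 log units; beyond the scatter), so at this position exchanging 1-methyl-1H-imidazol-2-yl for a chlorophenyl counts for far more than which chlorophenyl is present. Nothing available explains why these numbers differ.

The compounds shown leave open whether the chlorine is needed at all, as they include neither a plain phenyl nor a fluorophenyl on the triple-bonded carbon. Going by these compounds, it also remains open whether a pyridyl group or an imidazolyl group lacking the methyl would give a number as high as that of compound 3.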